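This account rests on a few compounds, and the source may have more. Where it says the series, first, only, none or still open, it means among the compounds named here.

Of the compounds shown here, three sharing one core have been tested in an ADME assay on Raji cells (Homo sapiens) for cytotoxicity, with a stated time of 72 h; a higher number here means that more compound is needed for the effect, a lower number that less compound is needed. Compound 1 `Cc1cc(NC(=O)Nc2ccc(F)c(F)c2)c2ccccc2n1` gives only a limit of the assay, > 25000 nM. Among the measured compounds shown here, compound 2 `COC(=O)c1ccc(NC(=O)Nc2cc(C)nc3ccccc23)cc1` gives 17000 nM and compound 3 `Cc1cc(NC(=O)Nc2cccc(C(F)(F)F)c2)c2ccccc2n1` gives 10000 nM, so compound 2 lies within the usual scatter of compound 3, the only other compound with a number. Compound 4 `Cc1cc(NC(=O)Nc2ccc(N)cc2)c2ccccc2n1` is not yet measured. It carries amino in place of methoxycarbonyl on an aromatic carbon of compound 2, para to a large group: amino in place of methoxycarbonyl on an aromatic carbon. For the measured compounds named here, no measured pair shows this change, so in this assay only a small shift toward a lower number, not beyond the scatter, is expected from compound 2 at 17000 nM. The expected change is a 1.4-fold lower number from compound 2 to compound 4 (0.15 log units; within the scatter). For compound 4 the estimate is 12000 nM, within an expected range of 4000 nM to 25000 nM.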

Compound 4, half-maximal effective concentration: > 25000 nM
Compound 4: a limit, no number; the forecaster's own chance of this, stated with the estimate: 25%; middle value at least 2.0-fold (0.31 log units) from the limit.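

In this assay, amino in place of methoxycarbonyl on an aromatic carbon, para to a large group, gives the first step read at this position: an at least 1.4-fold higher number from compound 2 to compound 4 (0.16 log units; that floor lies within the scatter). Compound 4 gives only a limit of the assay, so this step has a floor but no size: the limit of > 25000 nM in this assay, at which 2 of the 4 values shown sit.

On these data alone, it remains open how far compound 4 truly lies from compound 2. As far as these compounds go, it also remains open whether a carboxylic acid or an acetamide on this carbon would give a number inside the range of the assay.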